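A few compounds are considered here, and "the series" means these few. Any claim that something is new, unique, unknown or untested is made for them only; others in the source may bear on it.

Compound 1 `C/C(=N\NC(=O)COc1cccc2ccccc12)c1ccc([N+](=O)[O-])cc1`: 3.37
Compound 2 `C/C(=N\NC(=O)COc1cccc2ccccc12)c1ccccc1O`: 3.08
Compound 3 `COc1cc(/C=N/NC(=O)COc2cccc3ccccc23)cc(OC)c1O`: 3.23

All three share the same core and were measured in a physicochemical assay for lipophilicity, measured as octanol-water partition; a lower number here means a more polar compound, a higher number a more lipophilic compound. Compound 2 gives the lowest of the three numbers, yet its gap to compound 3 and the step of a number 0.29 log units lower from compound 1 to compound 2 (within the scatter) both lie within the scatter, so the three cannot truly be ranked in this assay.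

Compound 4 `C/C(=N\NC(=O)COc1cccc2ccccc12)c1ccccc1Br` has not yet been measured. It differs from compound 2 in one place: bromo in place of hydroxy on an aromatic carbon. Within the data shown here, the only measured step, a number 0.29 log units lower from compound 1 to compound 2 (within the scatter), exchanged a different group on that same carbon and moved the number little; it does not directly test a hydroxy-to-bromo swap, so there is no close precedent among the measured compounds.

Compound 4 is expected in this assay to give about 4.1, with a range from 3.6 to 4.6. That corresponds to an expected step of a number 1.02 log units higher from compound 2 to compound 4 (beyond the scatter), upward and beyond the scatter, starting from compound 2 at 3.08.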

Compound 4, partition coefficient: 4.44
Beside the measured number, compound 4's estimate is 0.34 log units below it; low and high end bracket the measured number.
By their numbers in this assay, from the lowest: compounds 2, 3 and 1 (each within the scatter of the next); then compound 4.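

In this assay, this aromatic carbon now proves able to move the number well beyond the scatter: bromo in place of hydroxy gives a number 1.36 log units higher from compound 2 to compound 4 (beyond the scatter) as a large step, for a swap of one heavy atom for one heavy atom. The 2-bromophenyl group also stands clear of the 4-nitrophenyl group, with a number 1.07 log units higher from compound 1 to compound 4 (beyond the scatter) as a second large step, whereas the earlier exchange between compound 1 and compound 2 stayed within the scatter. Among these compounds, no measurement at hand explains why bromo lifts the number so far.

From the compounds shown here alone, with a single bromo compound, it remains open whether this rise is particular to bromo or would also appear with chloro on the same carbon. An amine or a carboxylic acid at that place would show how far the number can fall from the value of compound 2.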